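Replacing 3-hydroxyphenyl with 4-fluorophenyl in compound 3

The compounds below may be only part of what the source reports. "The series", "measured", "known", "first", "only" and "open" are said of these compounds alone.

Compound 1 `COc1cc(C(=O)/C=C/c2ccc(N(C)C)cc2)cc(OC)c1OC`: 75000 nM
Compound 2 `COc1cc(C(=O)/C=C/c2cc(O)ccc2O)cc(OC)c1OC`: > 100000 nM
Compound 3 `COc1cc(C(=O)/C=C/c2cccc(O)c2)cc(OC)c1OC`: 49000 nM

All three compounds were tested in a functional assay on COLO 205 cells (Homo sapiens) for inhibition, read by MTT assay, with a stated time of 48 h; a higher number here means a weaker inhibitor, a lower number a stronger inhibitor. For compound 2, > 100000 nM is a limit of the assay and not a number. Compound 3, at 49000 nM, lies within the scatter of compound 1, at 75000 nM, so these two cannot be ranked against each other.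

The next compound is compound 4 `COc1cc(C(=O)/C=C/c2ccc(F)cc2)cc(OC)c1OC`, and the change is 4-fluorophenyl in place of 3-hydroxyphenyl on a double-bonded chain carbon bound to a double-bonded chain carbon. Going by the values given here, only one measured step bears on it: an at least 2.0-fold lower number from compound 2 to compound 3 (0.30 log units; that floor lies within the scatter). That step also takes a hydroxy group off an aromatic carbon, but no fluorine enters there, so it is only a loose guide. With that single step to go on, no change beyond the scatter is expected in this assay. The expected change is a 1.2-fold lower number from compound 3 to compound 4 (0.09 log units; within the scatter). For compound 4 the estimated value is 40000 nM. The expected range for compound 4 runs from 12000 nM to 100000 nM.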

Compound 4, half-maximal inhibitory concentration: 25700 nM
Compound 4: middle estimate off by 1.6-fold (0.19 log units), on the high side; low and high end bracket the measured number.
By their numbers in this assay, from the lowest: compounds 4, 3 and 1 (each within the scatter of the next, the first and the last beyond it). At a limit, above all of these: compound 2.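

In this assay, putting 4-fluorophenyl in place of 3-hydroxyphenyl gives a 1.9-fold lower number from compound 3 to compound 4 (0.28 log units; within the scatter), so the ring without a hydrogen-bond donor cannot be told apart from the ring with one, and this position does not appear to depend on that hydroxy group. Two other steps do clear the scatter, a 2.9-fold lower number from compound 1 to compound 4 (0.47 log units; beyond the scatter) and an at least 3.8-fold lower number from compound 2 to compound 4 (0.59 log units; beyond the scatter), so the fluoro ring stands modestly apart from the dimethylamino ring and the 2,5-dihydroxyphenyl ring. Compound 2 stands at a limit of the assay and not at a number, which makes that second step a floor: the limit of > 100000 nM in this assay, at which 1 of the 4 values shown sits.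

The compounds shown change the kind of group and its place on the ring together, so the two effects cannot be separated. A 3-fluorophenyl, a plain phenyl or a 4-chlorophenyl at this position would show whether the fluorine itself matters, or its place on the ring.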